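Dichloroacetanilides: from nitrile to methoxy on the ring

This account rests on a few compounds, and the source may have more. Where it says the series, first, only, none or still open, it means among the compounds named here.

Measured so far:
- Compound 1, `O=C(Nc1ccccc1)C(Cl)Cl`: "not determined" (no result reported) in a functional assay on Bel-7402 cells (Homo sapiens) for antiproliferative activity, read by MTT assay, with a stated time of 72 h; a higher number here means a weaker inhibitor, a lower number a stronger inhibitor
- Compound 2, `O=C(Nc1cccc(Br)c1)C(Cl)Cl`: 7720 nM
- Compound 3, `N#Cc1cccc(NC(=O)C(Cl)Cl)c1`: 48400 nM

Compound 1 carries the unsubstituted core and has no number. For the measured compounds named here, of the two numbers in hand, compound 3 holds the higher one; its nearest neighbour is compound 2, and the step of a 6.3-fold higher number from compound 2 to compound 3 (0.80 log units; beyond the scatter) is the only one-point change so far. That step concerns the cyano group now being exchanged, but it compares it with bromo, not with methoxy, so it gives only indirect guidance.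

Compound 4, `COc1cccc(NC(=O)C(Cl)Cl)c1`, is the next entry in this assay. It differs from compound 3 by methoxy in place of cyano on an aromatic carbon.

Nothing measured here bears directly on methoxy. Going by the values given here, the one relevant observation is that the nitrile gave compound 3 the weakest number so far, with compound 2 lying well below it. A change away from cyano is therefore expected to move the number downward rather than further up, but the data do not show how far; a value somewhere between compound 3 and compound 2 seems the reasonable working guess, and a result within the scatter of compound 3 cannot be excluded.

Compound 4 is expected to give 20000 nM, within 7000 nM to 60000 nM, meaning an estimated step of a 2.4-fold lower number from compound 3 to compound 4 (0.38 log units; beyond the scatter).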

Compound 4, half-maximal inhibitory concentration: 54800 nM
Estimate against measurement, compound 4: 2.7-fold (0.44 log units) below; the range from low to high includes it.
By their numbers in this assay, from the lowest: compound 2; then compounds 3 and 4 (each within the scatter of the next).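

In this assay the exchange of the nitrile for methoxy on this aromatic carbon gives a 1.1-fold higher number from compound 3 to compound 4 (0.05 log units; within the scatter) and does not separate the two groups, although they differ in their atoms and in the triple bond that leaves. Against bromo the picture is the same for both: methoxy in place of bromo gives a 7.1-fold higher number from compound 2 to compound 4 (0.85 log units; beyond the scatter) and points the same way as a 6.3-fold higher number from compound 2 to compound 3 (0.80 log units; beyond the scatter) for the nitrile, so among these three groups at this position only bromo stands apart, with the lower number. No measurement of any other property accompanies these compounds that could account for this result.

On these data alone, whether bromo is alone in this remains open, since a chloro, an amine or a hydroxyl group on the same aromatic carbon could either join it or fall with the nitrile and methoxy compounds, and the same groups on another carbon of the ring are equally unknown. Compound 1 gives "not determined" (no result reported) here, so the steps from the core of compound 1 to each substituted compound cannot be read, and no substituent can be judged against the unsubstituted ring.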